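From trifluoromethyl to 4-methoxyphenyl on compound 1

The source may hold more compounds than are shown below. What is called first, only, known or untested is meant among the compounds shown, and "the series" means these compounds.

In an ADME assay on HCT-116 cells (Homo sapiens) for cytotoxicity, read by CellTiter-Glo, with a stated time of 72 h (a higher number here means a weaker inhibitor, a lower number a stronger inhibitor), compound 1 `CC1CCN(C2CCN(S(=O)(=O)c3cccc(C(F)(F)F)c3)CC2)CC1` gives > 5000 nM, which is a limit and not a number. Compound 2 `CC1CCN(C2CCN(S(=O)(=O)c3ccccc3Br)CC2)CC1` gives > 5000 nM, also a limit. Compound 3 `COc1ccccc1-c1ccc(S(=O)(=O)N2CCC(N3CCC(C)CC3)CC2)cc1` gives > 5000 nM, again a limit. Compound 1 therefore has no numerical standing among these compounds: the limit of > 5000 nM in this assay, at which 3 of the 3 values shown sit.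

Compound 4 `COc1ccc(-c2cccc(S(=O)(=O)N3CCC(N4CCC(C)CC4)CC3)c2)cc1` carries 4-methoxyphenyl in place of trifluoromethyl on an aromatic carbon, meta to a large group: 4-methoxyphenyl in place of trifluoromethyl on an aromatic carbon. Within the data shown here, no measured step is available to size this change. The expectation rests on compound 1, whose > 5000 nM is a limit. In this assay, the expected step that the limit leaves unreadable from compound 1 to compound 4 is none beyond the scatter, and another limit is likely. Compound 4 is estimated at 6000 nM, with an expected range of 2500 nM to 12000 nM.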

Compound 4, half-maximal inhibitory concentration: > 5000 nM
Compound 4: no number, only a limit; the forecaster's own chance of this, stated with the estimate: 80%; the middle value is on the limit's open side.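

No step from compound 1 to compound 4 can be read, as both carry only a limit in this assay: the limit of > 5000 nM in this assay, at which 4 of the 4 values shown sit.

The compounds shown leave open how far 4-methoxyphenyl in place of trifluoromethyl shifts the read-out, and whether any compound here has a measurable value in this assay.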